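The source may hold more compounds than are shown below. What is called first, only, known or untested is meant among the compounds shown, and "the series" means these compounds.

Measured compounds in this series:

- compound 1, `Cc1ccc(-c2ccc(F)cc2)n1-c1ccc(-c2nc3ccccc3s2)cc1`: 40000 nM
- compound 2, `Cc1ccc(-c2ccc(C)n2-c2ccc(-c3nc4ccc(F)cc4s3)cc2)cc1`: 33600 nM

Both numbers come from an ADME assay on MCF-10A cells (Homo sapiens) for cytotoxicity, read by MTT assay, with a stated time of 72 h; on this read-out higher numbers stand for weaker inhibition and lower numbers for stronger inhibition. Compound 1 gives 40000 nM and compound 2 gives 33600 nM; the two values sit within the usual scatter of each other, so neither compound is separated from the other on this read-out, and nothing can be said about order between them. Compound 2 is therefore simply one of two closely matched weak inhibitors.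

Compound 3, `Cc1ccc(-c2ccc(F)cc2)n1-c1ccc(-c2nc3ccc(F)cc3s2)cc1`, has not been measured. Relative to compound 2 the change is fluoro in place of methyl on an aromatic carbon. Compound 3 combines the 4-fluorophenyl of compound 1 with the fluoro-substituted half of the shared core of compound 2. Within the data shown here, no step between measured compounds is available for this change, and the two measured values themselves lie within the scatter, so the expectation is a step in this assay of no size beyond the scatter, in no particular direction. For compound 3 the estimated value in this assay is 38000 nM, with a range of 19000 nM to 76000 nM; the expected step from compound 2 to compound 3 is a 1.1-fold higher number from compound 2 to compound 3 (0.05 log units; within the scatter).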

Compound 3, half-maximal inhibitory concentration: 37800 nM
The estimate for compound 3 lay 1.0-fold (0.00 log units) above the measured number; measured number inside the range.
By their numbers in this assay, from the lowest: compounds 2, 3 and 1 (each within the scatter of the next).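

In this assay, the change from 4-methylphenyl to 4-fluorophenyl, para to a large group, gives a 1.1-fold higher number from compound 2 to compound 3 (0.05 log units; within the scatter), so exchanging methyl for fluoro at this position does not separate the two compounds. The other single change, a fluoro added to the shared core, gives a 1.1-fold lower number from compound 1 to compound 3 (0.02 log units; within the scatter), and this too does not separate its pair on this read-out. Compound 1 and compound 2 differ in more than one place and could not isolate either change, whereas compound 3 links them through two single changes, neither of which moves the number beyond the scatter. No supporting measurement is available to explain these readings.

Only methyl and fluoro are shown at this position, so it remains open whether a different group there, such as an amine or a carboxylic acid, would give a step beyond the scatter. The compounds also leave open whether a longer chain in place of the methyl on the shared core would change the number in this assay.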